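Amino to Nitro on the Aryl Arm of Compound 3

The source may hold more compounds than are shown below. What is called first, only, known or untested is meant among the compounds shown, and "the series" means these compounds.

Compound 1 `COc1cc(-n2nnnc2-c2ccc(OCC3CC(c4cccc(Cl)c4)=NO3)c(N)c2)cc(OC)c1OC`: 1340 nM
Compound 2 `COc1cc(-n2nnnc2-c2ccc(OCC3CC(c4ccc(C(F)(F)F)cc4)=NO3)c(N)c2)cc(OC)c1OC`: 1220 nM
Compound 3 `COc1ccc(C2=NOC(COc3ccc(-c4nnnn4-c4cc(OC)c(OC)c(OC)c4)cc3N)C2)cc1N`: 2080 nM

All three share one core and differ only in the aryl group on a carbon with a double bond to nitrogen. In a functional assay on A549 cells (Homo sapiens) for cytotoxicity, read by MTT assay, with a stated time of 48 h (a higher number here means a weaker inhibitor, a lower number a stronger inhibitor), compound 3 gives the highest of the three numbers, yet a 1.6-fold higher number from compound 1 to compound 3 (0.19 log units; within the scatter) and a 1.7-fold higher number from compound 2 to compound 3 (0.23 log units; within the scatter) both stay within the scatter, so no order among them can be claimed.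

Compound 4 `COc1ccc(C2=NOC(COc3ccc(-c4nnnn4-c4cc(OC)c(OC)c(OC)c4)cc3N)C2)cc1[N+](=O)[O-]` keeps the 4-methoxyphenyl arm of compound 3 but carries nitro in place of amino on an aromatic carbon. Among the measured compounds shown here, no measured step swaps one group for another on this arm; the only steps known exchange the whole aryl group, and each of them stayed within the scatter. The expected step of a 1.2-fold lower number from compound 3 to compound 4 (0.06 log units; within the scatter) is therefore small, in no firm direction. Compound 4 is estimated at 1800 nM, with a range from 800 nM to 4000 nM.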

Compound 4, half-maximal inhibitory concentration: 2220 nM
Beside the measured number, compound 4's estimate is 1.2-fold (0.09 log units) below it; measured number inside the range.
By their numbers in this assay, from the lowest: compounds 2, 1, 3 and 4 (each within the scatter of the next).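

Unlike the earlier steps, which exchange the whole aryl group, this one changes a single group on the arm, and in this assay it gives a 1.1-fold higher number from compound 3 to compound 4 (0.03 log units; within the scatter). The whole-arm exchanges, a 1.8-fold higher number from compound 2 to compound 4 (0.26 log units; within the scatter) and a 1.7-fold higher number from compound 1 to compound 4 (0.22 log units; within the scatter), also stay within the scatter, so amino and nitro at this position cannot be told apart here. No measured evidence bears on this result. On these data alone, whether a hydroxyl, a methyl or an acetamide at this position would move the number beyond the scatter remains open.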